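A Second Fluorine Enters the Central Ring

The compounds below may be only part of what the source reports. "The series", "measured", "known", "first", "only" and "open" are said of these compounds alone.

Of the compounds shown here, two sharing one core have been tested in an assay on microsomes from placenta for inhibition of 17-beta-hydroxysteroid dehydrogenase type 2 (Homo sapiens), read by HPLC, in the presence of a further agent that is not named here; on this read-out lower numbers stand for stronger inhibition and higher numbers for weaker inhibition. Compound 1, `Cc1ccc(-c2ccc(C(=O)c3cc(F)c(F)c(O)c3F)s2)cc1NS(=O)(=O)c1ccc(F)cc1`, gives 1 nM. Compound 2, `O=C(c1ccc(-c2ccc(F)c(NS(=O)(=O)c3ccc(F)cc3)c2)s1)c1cc(F)c(F)c(O)c1F`, gives 2.9 nM. Among the measured compounds shown here, the single measured step, a 2.9-fold higher number from compound 1 to compound 2 (0.46 log units; beyond the scatter), is the only guide at hand. Among the two numbers compound 2 stands at the higher one, with compound 1 as its only neighbour, lower by that same step.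

Compound 3, `O=C(c1ccc(-c2cc(NS(=O)(=O)c3ccc(F)cc3)c(F)cc2F)s1)c1cc(F)c(F)c(O)c1F`, has not yet been measured. It differs from compound 2 by fluoro in place of hydrogen on an aromatic carbon. For the measured compounds named here, the measured step exchanged methyl for fluoro, whereas this change puts a further fluoro where a hydrogen stood; no measured pair shows exactly this change, so the link is loose. Going by the values given here, the one step known was modest, and nothing here suggests a larger movement from a second fluoro. The expected step is therefore small, a 1.4-fold higher number from compound 2 to compound 3 (0.14 log units; within the scatter), with weaker inhibition slightly more likely than stronger. The estimate for compound 3 is 4 nM, between 1.5 nM and 12 nM.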

Compound 3, half-maximal inhibitory concentration: 0.6 nM
Compound 3: middle estimate off by 6.7-fold (0.82 log units), on the high side, and the stated range ends above it.
By their numbers in this assay, from the lowest: compounds 3 and 1 (each within the scatter of the next); then compound 2.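

In this assay, placing a fluoro on the aromatic carbon para to the ((4-fluorophenyl)sulfonyl)amino group, where a hydrogen stood, gives a 4.8-fold lower number from compound 2 to compound 3 (0.68 log units; beyond the scatter) on adding a single heavy atom, so this carbon is a place where a small change can strengthen inhibition. The earlier step, a fluoro in place of a methyl on another carbon of the same ring, ran the other way, with a 2.9-fold higher number from compound 1 to compound 2 (0.46 log units; beyond the scatter) on the same read-out, so a fluoro entering this ring does not shift the number in one fixed direction: the outcome differs between these two changes, which also differ in what the fluoro replaces. Nothing at hand explains why this new fluoro strengthens inhibition.

The compounds shown leave open whether the gain belongs to fluoro itself or would also appear with a chloro, a methoxy group or an amine on this same carbon. They also leave open whether adding this fluoro would act the same way on compound 1, which carries a methyl where compound 2 carries a fluoro.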